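Chalcone-type quinolines: swapping the ketone aryl group

The source may report more compounds than this note shows. Statements on the series, on what has been measured and on what is new or still open speak of the compounds shown alone.

Measured so far:
Compound 1, `COc1ccc(-c2cc3ccccc3nc2/C=C/C(=O)c2ccc(O)cc2)cc1`, gives 6350 nM in a functional assay on MDA-MB-231 cells (Homo sapiens) for antiproliferative activity, read by XTT assay, with a stated time of 72 h; on this read-out lower numbers stand for stronger inhibition and higher numbers for weaker inhibition.
Compound 2, `COc1ccc(-c2cc3ccccc3nc2/C=C/C(=O)c2ccc(OC)c(OC)c2)cc1`, gives 4790 nM in this assay.
Compound 3, `COc1ccc(-c2cc3ccccc3nc2/C=C/C(=O)c2ccccn2)cc1`, gives 740 nM in this assay.

Compound 3 stands lowest of the three, with compound 2 nearest and compound 1 furthest. The steps that lead to it were an 8.6-fold lower number from compound 1 to compound 3 (0.93 log units; beyond the scatter) and a 6.5-fold lower number from compound 2 to compound 3 (0.81 log units; beyond the scatter), while a 1.3-fold lower number from compound 1 to compound 2 (0.12 log units; within the scatter). Compound 4, `COc1ccc(-c2cc3ccccc3nc2/C=C/C(=O)c2c[nH]c3ccccc23)cc1`, differs from compound 3 by 1H-indol-3-yl in place of pyridin-2-yl on a carbonyl carbon. Going by the values given here, no measured step tests this particular exchange; the two informative steps only show that the group on the carbonyl carbon matters. The estimate for compound 4 is therefore uncertain and leans toward a somewhat higher number, expressed as a 3.4-fold higher number from compound 3 to compound 4 (0.53 log units; beyond the scatter). Compound 4 is expected to give about 2500 nM, within a range from 600 nM to 10000 nM.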

Compound 4, half-maximal inhibitory concentration: > 10000 nM
Compound 4: no number, only a limit; the forecaster's own chance of this, stated with the estimate: 5%; middle value at least 4.0-fold (0.60 log units) from the limit.
By their numbers in this assay, from the lowest: compound 3; then compounds 2 and 1 (each within the scatter of the next). At a limit, above all of these: compound 4.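

In this assay compound 4 gives > 10000 nM, which is a limit of the assay and not a number. Exchanging the group on the carbonyl carbon can therefore raise the number sharply as well as lower it: 1H-indol-3-yl gives an at least 13-fold higher number from compound 3 to compound 4 (1.13 log units; beyond the scatter) and an at least 2.0-fold higher number from compound 2 to compound 4 (0.31 log units; beyond the scatter). The third step, an at least 1.5-fold higher number from compound 1 to compound 4 (0.19 log units; that floor lies within the scatter), cannot be read as a real difference.

Still open, as far as these compounds go, is whether the low number of compound 3 depends on the ring nitrogen of pyridin-2-yl, which a plain phenyl or pyridin-3-yl group would help test. Also open, from the compounds shown here alone, is whether the extra ring or the hydrogen-bond donor of 1H-indol-3-yl matters more.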